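The compounds below may be only part of what the source reports. "The series", "measured", "known", "first", "only" and "open" are said of these compounds alone.

Measured compounds:
- compound 1 `C1=C(c2cncc(Oc3ccccc3)c2)CC2CNCC1C2`: 4.8 nM
- compound 2 `CC(C)Oc1cncc(C2=CC3CNCC(C2)C3)c1`: 2.6 nM

In an in vitro assay on HEK-293T cells for displacement of a labelled ligand from Neuronal acetylcholine receptor; alpha3/alpha6/beta2/beta3 (Homo sapiens) (on this read-out lower numbers stand for stronger inhibition and higher numbers for weaker inhibition), compound 2 gives 2.6 nM, the lower of the two numbers, while compound 1 gives 4.8 nM. Within the data shown here, the only step between these two, a 1.8-fold lower number from compound 1 to compound 2 (0.27 log units; within the scatter), changes the group on the ether oxygen and not the amine, so the two compounds cannot be told apart on this read-out with confidence.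

Compound 3 `CC(C)Oc1cncc(C2=CC3CC(C2)CN(C)C3)c1` keeps the whole of compound 2 and differs in one place: methyl in place of hydrogen on an amine nitrogen in a ring. That is, the ring amine that carried a hydrogen now carries a methyl group. Among the measured compounds shown here, no measured step touches this amine; the step from compound 1 to compound 2 tells nothing about it. What is known is only that the secondary amine in compound 1 and compound 2 goes together with low numbers in this assay. For the measured compounds named here, with no step on the amine to lean on, the expectation must stay wide, and a modest rise in the number is the estimate, as expressed by a 3.8-fold higher number from compound 2 to compound 3 (0.59 log units; beyond the scatter). Compound 3 is therefore expected to give about 10 nM in this assay, within a range from 3 nM to 40 nM.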

Compound 3, inhibition constant: 690 nM
Compound 3: middle estimate off by 69-fold (1.84 log units), on the low side, outside the stated range (above it).
By their numbers in this assay, from the lowest: compounds 2 and 1 (each within the scatter of the next); then compound 3.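

Putting methyl in place of hydrogen on the amine nitrogen in the ring gives a 270-fold higher number from compound 2 to compound 3 (2.42 log units; beyond the scatter) in this assay, so on this core a change of a single carbon at this nitrogen is enough to weaken inhibition sharply. The earlier swap on the ether oxygen, from phenyl to isopropyl, is a much larger change in group yet gives only a 1.8-fold lower number from compound 1 to compound 2 (0.27 log units; within the scatter), so in these compounds the read-out responds far more strongly to the group on the amine nitrogen than to the one on the oxygen. Nothing available here explains why a methyl group on this nitrogen has so large an effect.

The compounds shown leave open how an ethyl group, a longer chain or an acetyl group on this nitrogen would read, and so whether any group other than hydrogen can sit there with a low number. Among these compounds, the methyl step is also seen only with isopropyl on the ether oxygen, so it remains open whether a step of the same size would appear with the phenyl group of compound 1.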